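Dropping the Methyl: From Compound 3 to Compound 4

The source may report more compounds than this note shows. Statements on the series, on what has been measured and on what is new or still open speak of the compounds shown alone.

Measured so far in a functional assay on HeLa cells (Homo sapiens) for cytotoxicity, read by MTT assay, with a stated time of 72 h, tested at 3 uM; a lower number here means less inhibition of growth, a higher number more inhibition of growth at the concentration tested:
Compound 1 `N/C(=N\NC(=S)N1CCN(c2ccccn2)CC1)c1ccc(F)cn1` gives 77.3%.
Compound 2 `Cc1ccnc(/C(N)=N/NC(=S)N2CCOCC2)c1` gives 44.7%.
Compound 3 `Cc1cccc(/C(N)=N/NC(=S)N2CCSCC2)n1` gives 54.6%.

Among these three numbers, compound 3 stands second highest. Its number and that of compound 2 lie within the usual scatter of each other, so the two cannot be told apart; compound 1 sits higher by a gap beyond the scatter.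

Compound 4 `N/C(=N\NC(=S)N1CCSCC1)c1ccccn1` differs from compound 3 in one place: hydrogen in place of methyl on an aromatic carbon. Going by the values given here, no measured pair here isolates this change, so there is no earlier step to lean on. Removing a single carbon at the ring edge is a modest alteration; the expected step in this assay is a number 4.6 percentage points lower from compound 3 to compound 4 (within the scatter), with no direction clear beyond the scatter. Compound 4 is therefore estimated at 50%, with a range from 30% to 70%.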

Compound 4, percent growth inhibition at one concentration: 39.7%
Compound 4: the middle estimate sits 10.3 percentage points above what was measured, within the range that was stated.
By their numbers in this assay, from the lowest: compounds 4, 2 and 3 (each within the scatter of the next, the first and the last beyond it); then compound 1.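

Replacing methyl with hydrogen on this aromatic carbon, next to the ring nitrogen, gives a number 14.9 percentage points lower from compound 3 to compound 4 (beyond the scatter) in this assay and so shows that this single carbon counts for growth inhibition at the concentration tested. Going by these compounds alone, no earlier pair could show this, since none isolated a change at this place. What lies behind the step stays unexplained, as no measurement here speaks to it.

As far as these compounds go, whether an ethyl group, a methoxy group or an amine on the same carbon would match or exceed the methyl remains open. Also open, from the compounds shown here alone, is whether the methyl has a similar effect when the rest of the molecule differs.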